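A few compounds are considered here, and "the series" means these few. Any claim that something is new, unique, unknown or untested is made for them only; others in the source may bear on it.

Compound 3 `Oc1ccccc1-c1cc(-c2cccc(C(F)(F)F)c2)cc(-c2ccccc2O)n1` is one of three analogues measured in a functional assay on T47D cells (Homo sapiens) for inhibition; a higher number here means a weaker inhibitor, a lower number a stronger inhibitor. In this assay compound 3 gives > 50000 nM, which is a limit of the assay rather than a number. Compound 1 `Oc1ccccc1-c1cc(-c2ccc(F)cc2)cc(-c2ccccc2O)n1` also gives only a limit, > 50000 nM. Compound 2 `Oc1cccc(-c2cc(-c3ccc(F)cc3)cc(-c3ccccc3O)n2)c1` likewise gives only a limit, > 50000 nM. All three values sit at the limit of > 50000 nM in this assay, at which 3 of the 3 values shown sit, so the step from compound 1 to compound 2, a step that the two limits leave unreadable from compound 1 to compound 2, and the step from compound 1 to compound 3, a step that the two limits leave unreadable from compound 1 to compound 3, cannot be sized. Compound 4 `Oc1cccc(-c2cc(-c3cccc(C(F)(F)F)c3)cc(-c3ccccc3O)n2)c1` differs from compound 3 by 3-hydroxyphenyl in place of 2-hydroxyphenyl on an aromatic carbon. This is the same exchange as from compound 1 to compound 2, which left no readable size. Compound 4 is therefore expected to stay at the limit, with a step that the limit leaves unreadable from compound 3 to compound 4 showing nothing beyond the scatter. The value of compound 4 is estimated at 80000 nM, between 30000 nM and 300000 nM.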

Compound 4, half-maximal inhibitory concentration: 6340 nM
Compound 4: middle estimate off by 13-fold (1.10 log units), on the high side; the whole stated range lies above it.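

In this assay, 3-hydroxyphenyl in place of 2-hydroxyphenyl next to the ring nitrogen turns out to matter, giving an at least 7.8-fold lower number from compound 3 to compound 4 (0.89 log units; beyond the scatter). With 3-hydroxyphenyl present, the other exchange also shows an effect, giving an at least 7.8-fold lower number from compound 2 to compound 4 (0.89 log units; beyond the scatter). Each exchange alone left the value at the limit, and only the two together gave a number: the limit of > 50000 nM in this assay, at which 3 of the 4 values shown sit.

On these data alone, whether an amine or a carboxylic acid in place of the hydroxyl of 3-hydroxyphenyl would keep this gain remains open. As far as these compounds go, the full size of both steps also stays open, as compound 2 and compound 3 give only limits.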